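The source may report more compounds than this note shows. Statements on the series, on what has been measured and on what is new or still open speak of the compounds shown alone.

Measured compounds in a functional assay on MCF7 cells (Homo sapiens) for cytotoxicity, read by MTT assay, with a stated time of 48 h; a higher number here means a weaker inhibitor, a lower number a stronger inhibitor:
- compound 1 `O=C(Nc1nc2ccc(F)cc2s1)c1cc(-c2ccc(F)cc2)n2nc(-c3ccccc3)cc2n1`: 22900 nM
- compound 2 `COc1ccc(-c2cc(C(=O)Nc3nc4ccc(F)cc4s3)nc3cc(-c4ccccc4)nn23)cc1`: 35500 nM
- compound 3 `COc1cc(-c2cc(C(=O)Nc3nc4ccc(F)cc4s3)nc3cc(-c4ccccc4)nn23)cc(OC)c1OC`: 27500 nM

Compound 1 has the smallest of the three numbers in this assay, but it is not separated from the others: the step of a 1.6-fold higher number from compound 1 to compound 2 (0.19 log units; within the scatter) and the step of a 1.2-fold higher number from compound 1 to compound 3 (0.08 log units; within the scatter) both stay within the scatter, as does a 1.3-fold lower number from compound 2 to compound 3 (0.11 log units; within the scatter). The three measured compounds differ only in the aryl group on the shared core, and none of those changes moved the number.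

Compound 4 `Cc1cc2nc(NC(=O)c3cc(-c4ccc(F)cc4)n4nc(-c5ccccc5)cc4n3)sc2cc1C` is not yet measured. It differs from compound 1 at the other end of the molecule: 5,6-dimethyl-1,3-benzothiazol-2-yl in place of 6-fluoro-1,3-benzothiazol-2-yl on an amide-type nitrogen. Among the measured compounds shown here, no measured step touches this part of the structure, so the three steps above give no direct guidance; they only show that this series has so far been flat in this assay. Given that, the expectation for compound 4 is a number close to that of compound 1, with no step beyond the scatter, a 1.0-fold higher number from compound 1 to compound 4 (0.00 log units; within the scatter). The estimate for compound 4 in this assay is 23000 nM, with a range from 8000 nM to 70000 nM.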

Compound 4, half-maximal inhibitory concentration: 17000 nM
Estimate against measurement, compound 4: 1.4-fold (0.13 log units) above; low and high end bracket the measured number.
By their numbers in this assay, from the lowest: compounds 4, 1, 3 and 2 (each within the scatter of the next, the first and the last beyond it).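

Among the compounds shown here, the group on the amide-type nitrogen varies here for the first time: 5,6-dimethyl-1,3-benzothiazol-2-yl in place of 6-fluoro-1,3-benzothiazol-2-yl gives a 1.3-fold lower number from compound 1 to compound 4 (0.13 log units; within the scatter) in this assay. Removing the fluorine and adding two methyl groups therefore leaves the number within the scatter, so this end of the molecule has so far stayed as flat as the aryl position on the shared core. Nothing available bears on why this exchange leaves the number unmoved.

For the compounds shown here, only this one exchange at the amide-type nitrogen can be read, so the effect of an amine, a carboxylic acid or a longer chain in place of the methyl groups remains open. Also open, on these data alone, is whether the 5,6-dimethyl group would behave the same way alongside the 4-methoxyphenyl or 3,4,5-trimethoxyphenyl groups.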